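Removing the Pyrazole From a Fused Imidazole Core

The compounds below may be only part of what the source reports. "The series", "measured", "known", "first", "only" and "open" are said of these compounds alone.

Compound 1, `Cc1oncc1-c1cccc2c1CCC2c1ncc[nH]1`: 63%
Compound 2, `Cc1n[nH]cc1-c1cccc2c1CCC2c1ncc[nH]1`: 91%

In a functional assay on CHO cells for agonist activity at Alpha-1A adrenergic receptor (Homo sapiens), read by FLIPR and calcium flux (a lower number here means a smaller maximal response, a higher number a larger maximal response), compound 1 gives 63%, while compound 2 gives 91%. Going by the values given here, the single measured step, a number 28 percentage points higher from compound 1 to compound 2 (beyond the scatter), comes from 3-methyl-1H-pyrazol-4-yl in place of 5-methyl-1,2-oxazol-4-yl on an aromatic carbon. Among the compounds with values here, compound 2 therefore stands highest of the two numbers known, with compound 1 as its only and nearest neighbour.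

Compound 3, `c1ccc2c(c1)CCC2c1ncc[nH]1`, has not yet been measured. It differs from compound 2 in that (hydrogen in place of 3-methyl-1H-pyrazol-4-yl on an aromatic carbon). Within the data shown here, no measured step removes an entire aromatic substituent from this position, so the step is only loosely anchored. Among the measured compounds shown here, the one known step, a number 28 percentage points higher from compound 1 to compound 2 (beyond the scatter), shows that exchanging one five-membered ring for another already shifts the maximal response beyond the scatter, so taking the ring away is expected to shift it as well, most likely downward, as a number 36 percentage points lower from compound 2 to compound 3 (beyond the scatter). For compound 3 the maximal response is estimated at 55%, within a wide range from 15% to 95%, reflecting the thin evidence.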

Compound 3, largest response reached (Emax), in percent of the reference or control that the assay uses: 54%
Beside the measured number, compound 3's estimate is 1 percentage points above it; the measured number falls inside the stated range.
By their numbers in this assay, from the lowest: compounds 3 and 1 (each within the scatter of the next); then compound 2.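

In this assay the removal of 3-methyl-1H-pyrazol-4-yl from the aromatic carbon amounts to a number 37 percentage points lower from compound 2 to compound 3 (beyond the scatter) and so takes away the higher maximal response seen with compound 2. Hydrogen in place of 5-methyl-1,2-oxazol-4-yl amounts to a number 9 percentage points lower from compound 1 to compound 3 (within the scatter) and so leaves that ring indistinguishable from hydrogen at this position, which the earlier pair could not show, as it revealed only that the two rings differ and not which of them departs from the unsubstituted core. Of the three groups, only 3-methyl-1H-pyrazol-4-yl therefore stands apart, although nothing available accounts for the difference between the two rings.

The compounds shown leave open whether the methyl group of 3-methyl-1H-pyrazol-4-yl contributes to the response, or whether the unmethylated pyrazol-4-yl ring would stand with compound 2 or with compound 1 and compound 3. They also leave open where a phenyl ring, an amine or a carboxylic acid on the same aromatic carbon would fall relative to these three compounds.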